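Aryl substituents on the imidazole nitrogen of the trimethoxyphenyl series

This account rests on a few compounds, and the source may have more. Where it says the series, first, only, none or still open, it means among the compounds named here.

Three analogues of a shared core carry different groups on an aromatic nitrogen of the five-membered ring. Compound 1 `COc1cc(-c2nccn2CC(C)C)cc(OC)c1OC` carries isobutyl there. In a functional assay on HCT-15 cells (Homo sapiens) for antiproliferative activity, read by MTT assay, with a stated time of 72 h (a lower number here means a stronger inhibitor, a higher number a weaker inhibitor), compound 1 gives > 100000 nM, which is a limit of the assay and not a number. Compound 2 `COc1cc(-c2nccn2S(=O)(=O)c2ccccc2)cc(OC)c1OC` carries phenylsulfonyl on the same nitrogen. In this assay compound 2 gives > 100000 nM, again a limit. Among the compounds with values here, compound 3 `COc1cc(-c2nccn2-c2ccc3[nH]ccc3c2)cc(OC)c1OC` carries an indolyl group on that nitrogen and is the only member with a measured number: in this assay compound 3 gives 4600 nM. Compound 1 therefore stands at the limit of > 100000 nM in this assay, at which 2 of the 3 values shown sit, and no numerical comparison between compound 1 and compound 3 is possible beyond stating that compound 3 returned a number and compound 1 did not.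

Compound 4 `COc1ccc(-n2ccnc2-c2cc(OC)c(OC)c(OC)c2)cc1` is not yet measured. It differs from compound 1 by 4-methoxyphenyl in place of isobutyl on an aromatic nitrogen. An aromatic ring on this nitrogen is expected to move the value into the measurable range, because compound 3 with an aromatic ring in the same place gives 4600 nM. Compound 4 is expected to give 3000 nM, within 400 nM to 30000 nM. This estimate means a step of an at least 33-fold lower number from compound 1 to compound 4 (1.52 log units; beyond the scatter) from the limit, with wide uncertainty given that only compound 3 provides a number.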

Compound 4, half-maximal inhibitory concentration: 1300 nM
For compound 4 the middle estimate is 2.3-fold (0.36 log units) above the measured one; measured number inside the range.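

In this assay, within the data shown here, 4-methoxyphenyl in place of isobutyl on an aromatic nitrogen gives an at least 76-fold lower number from compound 1 to compound 4 (1.88 log units; beyond the scatter), the first step that can be read for a change at this position, and it shows that the position responds strongly to this change. Compounds 3 and 4 both return a number with an aromatic ring attached directly to this nitrogen, but compound 2 goes against any wider reading that a phenyl ring alone is enough: with its phenyl ring attached through a sulfonyl, compound 2 gives > 100000 nM, which is a limit of the assay. The true size of the step remains unknown, because it starts from a limit and not from a number: the limit of > 100000 nM in this assay, at which 2 of the 4 values shown sit.

The compounds shown do not separate the contribution of the aromatic ring from that of its methoxy group, a question that an unsubstituted phenyl or a 4-hydroxyphenyl on the same nitrogen would address. Also open, going by these compounds, is whether a benzyl or a cyclohexyl group there would return a number, and so whether the ring must be aromatic and directly attached.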